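The compounds below may be only part of what the source reports. "The series", "measured", "known", "first", "only" and "open" are said of these compounds alone.

Compound 1 `COc1cccc(C(=O)n2c(-c3cn(C)c4ccccc34)nc3ccccc32)c1`: 10200 nM
Compound 2 `COc1cc(C(=O)n2c(-c3cn(C)c4ccccc34)nc3ccccc32)cc(OC)c1OC`: 2600 nM

In a functional assay on A549 cells (Homo sapiens) for inhibition, read by MTT assay, with a stated time of 24 h (on this read-out higher numbers stand for weaker inhibition of growth and lower numbers for stronger inhibition of growth), compound 1 stands at 10200 nM as the higher of the two numbers, and compound 2 at 2600 nM lies lower, beyond the usual scatter.

Compound 3 `Cn1cc(-c2nc3ccccc3n2C(=O)c2ccccc2Br)c2ccccc21` has not yet been measured. It carries 2-bromophenyl in place of 3-methoxyphenyl on a carbonyl carbon and otherwise keeps the core of compound 1 unchanged. For the measured compounds named here, no measured pair isolates this change, and no measured compound carries a 2-bromophenyl group. Going by the values given here, the two values show only that numbers can differ beyond the scatter when the group on that carbonyl carbon differs. With so little to go on, compound 1 at 10200 nM remains the anchor, and no step beyond the scatter is expected in this assay for this change. The expected step of a 1.5-fold lower number from compound 1 to compound 3 (0.16 log units; within the scatter) is therefore a small one, with a wide margin on either side. For compound 3 the estimated value is 7000 nM with an expected range (2500 nM to 20000 nM).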

Compound 3, concentration for 50% growth inhibition: 43200 nM
Beside the measured number, compound 3's estimate is 6.2-fold (0.79 log units) below it; the whole stated range lies below it.
By their numbers in this assay, from the lowest: compound 2; then compound 1; then compound 3.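

In this assay, for the compounds shown here, the swap of 3-methoxyphenyl for 2-bromophenyl on the carbonyl carbon gives a 4.2-fold higher number from compound 1 to compound 3 (0.63 log units; beyond the scatter) as the first step that isolates a single place; it is modest in size but lies beyond the scatter. With the core of compound 1 unchanged, this position is therefore not indifferent to the group it carries, and this particular change moves the series towards weaker inhibition of growth, with the entering group bringing bromine and the hydrogen-bond acceptor of the leaving group gone. Nothing measured here gives a reason for this step.

The change alters both the substituent and its numbered place on the phenyl ring, and the compounds shown do not separate these two contributions. Also open, on these data alone, is how the numbers would respond to a phenyl ring on that carbonyl carbon bearing an amine or a carboxylic acid, or to a longer chain in place of the phenyl ring, so a single step cannot yet be read as a trend for this position.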